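The source may hold more compounds than are shown below. What is called first, only, known or untested is meant among the compounds shown, and "the series" means these compounds.

In a functional assay on RKO cells (Homo sapiens) for cytotoxicity, read by resazurin assay, with a stated time of 72 h (on this read-out higher numbers stand for weaker inhibition and lower numbers for stronger inhibition), the three measured compounds gave:

compound 1, `COc1ccc(Nc2nc(-n3cnc4ccccc43)cs2)cc1`: > 100000 nM, which is a limit of the assay and not a number
compound 2, `COc1cccc(Nc2nc(-n3ccnc3C)cs2)c1`: 22500 nM
compound 3, `Cc1ccc(Nc2nc(-n3cc(C)nc3C)cs2)cc1`: 200 nM

Within the data shown here, compound 1 is the one compound here whose result is only a limit; it sits at the limit of > 100000 nM in this assay, at which 1 of the 3 values shown sits. Among the measured compounds shown here, compound 2 and compound 3 carry other groups on the shared core, so no single-point step between either of them and compound 1 is traced here, and their values show only that numbers within the working range of the assay were obtained for them.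

Compound 4, `Brc1ccc(Nc2nc(-n3cnc4ccccc43)cs2)cc1`, has not yet been measured in this assay. It differs from compound 1 in one place: bromo in place of methoxy on an aromatic carbon. For the measured compounds named here, with compound 1 known only as a limit, and no measured step showing how a change of this kind moves the read-out, the expected step of an at least 1.4-fold lower number from compound 1 to compound 4 (0.15 log units; that floor lies within the scatter) is set as small, within the scatter, with no direction claimed. Compound 4 is therefore expected to give about 70000 nM, somewhere between 15000 nM and 300000 nM, and it may well return only a limit again.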

Compound 4, half-maximal inhibitory concentration: > 100000 nM
Compound 4: a limit, no number (the forecaster's own chance of this, stated with the estimate: 55%); middle value at least 1.4-fold (0.15 log units) away from the limit.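

In this assay compound 4 gives > 100000 nM, a limit of the assay and not a number, just as compound 1 does, so no step can be read between compound 1 and compound 4: the limit of > 100000 nM in this assay, at which 2 of the 4 values shown sit. The compounds shown leave open whether bromo in place of methoxy moves the read-out at all, and in which direction.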